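Shrinking a ring on the amine: cyclohexyl to cyclopentyl

This account rests on a few compounds, and the source may have more. Where it says the series, first, only, none or still open, it means among the compounds named here.

Compound 1 `COc1cccc(-n2cc3nc(-c4cccnc4C)n(C[C@H]4CCCN(CC5CCCCC5)C4)c(=O)c3n2)c1`: 200 nM
Compound 2 `COc1ccc(-n2cc3nc(-c4ccccc4C)n(CC4CCCN(C(C)C)C4)c(=O)c3n2)cc1`: 7.3 nM

Of the compounds shown here, two have been measured in an assay on HEK293 cells for displacement of a labelled ligand from growth hormone secretagogue receptor type 1 (Homo sapiens), with a stated time of 60 min; on this read-out lower numbers stand for stronger inhibition and higher numbers for weaker inhibition. Compound 1 gives 200 nM and compound 2 gives 7.3 nM; compound 1 therefore carries the higher of the two numbers, and the gap between them lies beyond the usual scatter. The two compounds differ in several places at once, so no single change can be tied to that gap.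

Compound 3 `COc1cccc(-n2cc3nc(-c4cccnc4C)n(C[C@H]4CCCN(CC5CCCC5)C4)c(=O)c3n2)c1` has not been measured. It differs from compound 1 in one place only: cyclopentyl in place of cyclohexyl on a saturated chain carbon bound to an amine nitrogen in a ring. The rest of the molecule, including the shared core and the amine-bearing ring, is unchanged.

Among the compounds with values here, with no measured pair that isolates this kind of change, there is nothing in the data that points one way or the other. The expectation is that the step of no change at the digits printed from compound 1 to compound 3 (within the scatter) stays within the scatter, with compound 3 behaving much like compound 1. Compound 3 is estimated at 200 nM in this assay, with a likely range from 70 nM to 600 nM.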

Compound 3, half-maximal inhibitory concentration: 12 nM
The estimate for compound 3 lay 17-fold (1.22 log units) above the measured number; measured number below the stated range.
By their numbers in this assay, from the lowest: compounds 2 and 3 (each within the scatter of the next); then compound 1.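

In this assay, the group on this saturated chain carbon bound to an amine nitrogen in a ring proves to matter: replacing cyclohexyl with cyclopentyl gives a 17-fold lower number from compound 1 to compound 3 (1.22 log units; beyond the scatter). The two earlier compounds differ in several places, so their gap could not be tied to any one site, whereas this pair changes only a six-membered carbon ring to a five-membered one, with no hydrogen-bond donor, acceptor or net charge on either group, and everything else stays the same. The data shown offer no measurement that explains why this one change moves the number so far.

From the compounds shown here alone, it remains open whether the number would keep falling with a still smaller ring such as cyclobutyl, or how a phenyl group would compare at the same carbon. Within the data shown here, with only this one pair, it is also unknown whether the same swap would give a step of similar size on a different set of groups around the shared core.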